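Changing the Amide Substituent and Cell Growth Inhibition

The compounds below may be only part of what the source reports. "The series", "measured", "known", "first", "only" and "open" are said of these compounds alone.

Measured compounds:
Compound 1, `CCN(CC)S(=O)(=O)c1ccc(S(=O)(=O)N2CCC[C@@H](C(=O)NC3COC3)C2)cc1`: 13800 nM
Compound 2, `CCN(CC)S(=O)(=O)c1ccc(S(=O)(=O)N2CCC[C@@H](C(=O)NC)C2)cc1`: 13800 nM

The two measured compounds share one core and differ only in the group on the amide-type nitrogen. In a functional assay on BXPC-3 cells (Homo sapiens) for inhibition, read by MTT assay, with a stated time of 7 days (on this read-out higher numbers stand for weaker inhibition and lower numbers for stronger inhibition), compound 1 gives 13800 nM and compound 2 gives 13800 nM. Within the data shown here, the one measured step, no change at the digits printed from compound 1 to compound 2 (within the scatter), leaves the read-out where it was, so compound 2 stands level with compound 1 within the scatter of this assay.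

Compound 3, `CCN(CC)S(=O)(=O)c1ccc(S(=O)(=O)N2CCC[C@@H](C(=O)NC3CN(C(=O)OC(C)(C)C)C3)C2)cc1`, is not yet measured. It differs from compound 2 by 1-(tert-butoxycarbonyl)azetidin-3-yl in place of methyl on an amide-type nitrogen. Among the measured compounds shown here, the only step that bears on this is the one at the same amide-type nitrogen, no change at the digits printed from compound 1 to compound 2 (within the scatter), where a ring group and a methyl gave the same reading. That step is small, so no step beyond the scatter is expected in this assay for compound 3, although the entering group is considerably larger than either of the two groups already compared, which widens the uncertainty. The estimated step is no change at the digits printed from compound 2 to compound 3 (within the scatter). Compound 3 is therefore expected to give about 13800 nM, with a likely range from 5000 nM to 40000 nM.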

Compound 3, half-maximal inhibitory concentration: 1800 nM
The estimate for compound 3 lay 7.7-fold (0.88 log units) above the measured number, outside the stated range (below it).
By their numbers in this assay, from the lowest: compound 3; then compounds 1 and 2 (each within the scatter of the next).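

In this assay this amide-type nitrogen proves not to be indifferent to its substituent: placing 1-(tert-butoxycarbonyl)azetidin-3-yl there in place of methyl gives a 7.7-fold lower number from compound 2 to compound 3 (0.88 log units; beyond the scatter) in the read-out, and placing it there in place of oxetan-3-yl gives a 7.7-fold lower number from compound 1 to compound 3 (0.88 log units; beyond the scatter) in the same read-out. The level reading shared by the methyl and oxetan-3-yl compounds therefore does not extend to every group at this place, and a lower number here means stronger inhibition of cell growth. No supporting data bear on what lies behind this shift.

The entering group differs from methyl in several ways at once, with 11 heavy atoms, a four-membered ring and 2 hydrogen-bond acceptors, so the compounds shown leave open which part of it matters. An azetidin-3-yl ring with a free amine in place of the tert-butoxycarbonyl group, or a plain tert-butyl group on the amide-type nitrogen, would help separate the contribution of the ring from that of the tert-butoxycarbonyl part.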